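Trifluoromethyl on compound 1: a small step expected

The compounds below may be only part of what the source reports. "The series", "measured", "known", "first", "only" and "open" are said of these compounds alone.

compound 1 `CCN1CCc2c(sc(NC(=O)Nc3ccccc3)c2C(N)=O)C1`: > 25000 nM
compound 2 `CCN1CCc2c(sc(NC(=O)Nc3cccc(Cl)c3Cl)c2C(N)=O)C1`: 17400 nM

Compound 1 reaches only a limit of > 25000 nM in a functional assay (strain AB) with Danio rerio as the target, read by microscopy, with a stated time of 1 h (on this read-out lower numbers stand for an effect already at smaller amounts and higher numbers for an effect only at larger amounts of compound), and so offers no number to start from. Compound 3 `CCN1CCc2c(sc(NC(=O)Nc3ccc(C(F)(F)F)cc3)c2C(N)=O)C1` carries trifluoromethyl in place of hydrogen on an aromatic carbon, para to a large group (trifluoromethyl in place of hydrogen on an aromatic carbon). Going by the values given here, one measured step bears on this change: an at least 1.4-fold lower number from compound 1 to compound 2 (0.15 log units; that floor lies within the scatter) with 2,3-dichlorophenyl in place of phenyl on an amide-type nitrogen. Among the compounds with values here, compound 2 at 17400 nM holds the only number so far, and its group differs from the one in compound 3, so the guide is weak. In this assay a small move toward lower numbers is therefore expected, or none beyond the scatter, and compound 3 may also stop at the limit. The expected step is an at least 1.3-fold lower number from compound 1 to compound 3 (0.14 log units; that floor lies within the scatter) on this reasoning. For compound 3 the estimate is 18000 nM with an expected range from 7000 nM to 40000 nM around it.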

Compound 3, half-maximal effective concentration: 2910 nM
For compound 3 the middle estimate is 6.2-fold (0.79 log units) above the measured one; measured number outside the range, below it.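

In this assay, the compounds now show that a single group on the aromatic ring can move the read-out clearly: with trifluoromethyl in place of hydrogen, para to a large group, the result is an at least 8.5-fold lower number from compound 1 to compound 3 (0.93 log units; beyond the scatter). The earlier change on this ring, an at least 1.4-fold lower number from compound 1 to compound 2 (0.15 log units; that floor lies within the scatter), had shown no such clear move. The step remains open-ended, and its printed size is only a floor: the limit of > 25000 nM in this assay, at which 1 of the 3 values shown sits.

The compounds shown do not reveal whether this drop in the number is specific to trifluoromethyl or whether a smaller halogen such as fluorine, a methoxy group, a nitrile or a carboxylic acid at the same place would give a similar result. They also leave open whether the same change would have a comparable effect on a core carrying a different group in place of the ethyl chain.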